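Trimming the group on the carbonyl carbon of compound 3

This account rests on a few compounds, and the source may have more. Where it says the series, first, only, none or still open, it means among the compounds named here.

Of the compounds shown here, three sharing one core have been tested in a functional assay on MCF7 cells (Homo sapiens) for antiproliferative activity, read by MTT assay, with a stated time of 48 h; on this read-out lower numbers stand for stronger inhibition and higher numbers for weaker inhibition. Compound 1 (`C=CCN(C)C(=O)c1ccc(C(CC)(CC)c2ccc(OCCC(O)(CC)CC)c(C)c2)n1CC`) gives > 50000 nM, which is a limit and not a number. Compound 2 (`CCn1c(C(=O)Nc2ccc(OC(F)(F)F)cc2)ccc1C(CC)(CC)c1ccc(OCCC(O)(CC)CC)c(C)c1`) gives > 50000 nM, also a limit. Compound 3 (`CCC(C)C(NC(=O)c1ccc(C(CC)(CC)c2ccc(OCCC(O)(CC)CC)c(C)c2)n1CC)C(=O)OC`) gives > 50000 nM, again a limit.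

Compound 4 (`CCn1c(C(=O)N(C)CCO)ccc1C(CC)(CC)c1ccc(OCCC(O)(CC)CC)c(C)c1`) differs from compound 3 in one place: a group of 5 heavy atoms (3 carbon, 1 nitrogen, 1 oxygen; no ring) in place of a group of 10 heavy atoms (7 carbon, 1 nitrogen, 2 oxygen; no ring), on a carbonyl carbon. The nearest evidence comes from swaps at the same carbonyl carbon: a step that the two limits leave unreadable from compound 1 to compound 3, a step that the two limits leave unreadable from compound 2 to compound 3 and a step that the two limits leave unreadable from compound 1 to compound 2. None has a readable size, and the series stands at the limit of > 50000 nM in this assay, at which 3 of the 3 values shown sit. No change beyond the usual scatter is therefore expected, and the expected outcome is a number no higher from compound 3 to compound 4 (the limit leaves the size open). For compound 4 the estimate is 50000 nM, with an expected range of 20000 nM to 100000 nM.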

Compound 4, half-maximal inhibitory concentration: 2870 nM
Compound 4: the middle estimate sits 17-fold (1.24 log units) above what was measured, and the stated range ends above it.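

At this carbonyl carbon, (2-hydroxyethyl)(methyl)amino gives the first readable result in this assay, with an at least 17-fold lower number from compound 3 to compound 4 (1.24 log units; beyond the scatter). The same holds against the aryl amide, with an at least 17-fold lower number from compound 2 to compound 4 (1.24 log units; beyond the scatter), and against the allyl amide, where hydroxymethyl replaces vinyl, with an at least 17-fold lower number from compound 1 to compound 4 (1.24 log units; beyond the scatter). The group on this carbon can therefore move the series off its limit, where the other compounds remain: the limit of > 50000 nM in this assay, at which 3 of the 4 values shown sit.

From the compounds shown here alone, whether the hydroxyl itself matters, or the short chain that carries it, stays open. A (2-methoxyethyl)(methyl)amino or (3-hydroxypropyl)(methyl)amino group at this carbonyl carbon would bear on that.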